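The compounds below may be only part of what the source reports. "The series", "measured", "known", "first", "only" and "open" are said of these compounds alone.

Working notes on the series. In a functional assay on Jurkat cells (Homo sapiens) for cytotoxicity, read by luminescence and CellTiter-Glo, with a stated time of 3 days (a higher number here means a weaker inhibitor, a lower number a stronger inhibitor), compound 1 (`O=C(Nc1ccc(C(F)(F)F)cc1)c1cc(Cl)ccc1O`) gives 710 nM as its half-maximal inhibitory concentration, while compound 2 (`N#Cc1cc(Cl)ccc1NC(=O)c1ccc2cccnc2c1O`) gives 170 nM on the same read-out. Compound 2 thus holds the lower of the two numbers, and its gap to compound 1 lies beyond the usual scatter.

The next compound is compound 3 (`O=C(Nc1ccc(Cl)cc1)c1ccc2cccnc2c1O`), which differs from compound 2 by a single change (hydrogen in place of cyano on an aromatic carbon): hydrogen in place of cyano on an aromatic carbon, ortho to a large group and meta to a chloro group. Going by the values given here, no measured pair differs in one place only, so the effect of this change has not been observed directly. Among the compounds with values here, the only loose guide is compound 1, which also lacks cyano and gives 710 nM on a different core.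

A small rise in the number, near the edge of the scatter, is expected, with an estimated 1.8-fold higher number from compound 2 to compound 3 (0.25 log units; within the scatter) in this assay as the working figure. For compound 3 the expected value is 300 nM (estimated range 100 nM to 900 nM).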

Compound 3, half-maximal inhibitory concentration: 510 nM
Beside the measured number, compound 3's estimate is 1.7-fold (0.23 log units) below it; the measured number falls inside the stated range.
By their numbers in this assay, from the lowest: compound 2; then compounds 3 and 1 (each within the scatter of the next).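

In this assay the series now holds its first pair that differs in one place, and replacing cyano with hydrogen gives a 3.0-fold higher number from compound 2 to compound 3 (0.48 log units; beyond the scatter) on the shared core. This shows that the aromatic carbon ortho to a large group and meta to a chloro group is sensitive to this change: the step is modest in size but beyond the scatter, and the compound with the nitrile holds the lower number. Nothing measured here bears on the reason for this step.

Going by these compounds, with only cyano and hydrogen seen at this carbon, it remains open whether the step is specific to cyano or whether another group, such as fluoro, methyl or an amine, would give a number like that of either compound. On these data alone, it is also open whether the same exchange would give a step of similar size on the core of compound 1, and whether the chloro group contributes to the size of the step seen here.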